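Reshaping the amine side chain of compound 3

This account rests on a few compounds, and the source may have more. Where it says the series, first, only, none or still open, it means among the compounds named here.

Measured in a physicochemical assay for lipophilicity, measured as octanol-water partition, at pH 7.4 (on this read-out higher numbers stand for higher lipophilicity and lower numbers for lower lipophilicity), so far:
compound 1 `Cc1ccc2[nH]c(C(=O)N[C@H]3CN(S(=O)(=O)c4ccccc4)C[C@@H]3C(=O)NCCN(C)C)cc2c1` gives 2.1
compound 2 `Cc1ccc2[nH]c(C(=O)N[C@H]3CN(S(=O)(=O)c4ccccc4)C[C@@H]3C(=O)NC[C@H]3CCCN3)cc2c1` gives 1
compound 3 `Cc1ccc2[nH]c(C(=O)N[C@H]3CN(S(=O)(=O)c4ccccc4)C[C@@H]3C(=O)NC[C@H]3CCCN3C)cc2c1` gives 2.3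

Compound 3 matches compound 1 within the scatter, and only compound 2 falls clearly away from that pair. The unmeasured compound 4 `Cc1ccc2[nH]c(C(=O)N[C@H]3CN(S(=O)(=O)c4ccccc4)C[C@@H]3C(=O)N[C@@H]3CCCN(C)C3)cc2c1` has the same atoms as compound 3, joined differently: 1-methylpiperidin-3-yl in place of (1-methylpyrrolidin-2-yl)methyl on an amide-type nitrogen. Among the measured compounds shown here, the closest precedent is another swap of one side chain for a related one (a number 0.20 log units higher from compound 1 to compound 3 (within the scatter)). The large steps (a number 1.10 log units lower from compound 1 to compound 2 (beyond the scatter) and a number 1.30 log units higher from compound 2 to compound 3 (beyond the scatter)) both involve compound 2, which lacks the methyl on its ring amine nitrogen, and compound 4 keeps that methyl. The estimated step of a number 0.10 log units lower from compound 3 to compound 4 (within the scatter) is therefore expected to stay inside the scatter of this assay as well. Compound 4 is estimated at 2.2 (expected range 1.7 to 2.7).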

Compound 4, distribution coefficient: 2.7
Compound 4: the middle estimate sits 0.50 log units below what was measured; the range from low to high includes it.
By their numbers in this assay, from the lowest: compound 2; then compounds 1 and 3 (each within the scatter of the next); then compound 4.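

In this assay, joining the same atoms differently is enough to shift the number on this amide-type nitrogen: a number 0.40 log units higher from compound 3 to compound 4 (beyond the scatter). The 1-methylpiperidin-3-yl side chain also stands clear of the other two side chains, with a number 0.60 log units higher from compound 1 to compound 4 (beyond the scatter) and a number 1.70 log units higher from compound 2 to compound 4 (beyond the scatter), so compound 4 now holds the highest number of the series. Nothing measured here explains these shifts. Still open, on these data alone, is whether a 1-methylpiperidin-4-yl or a morpholine ring at this place would give a number near that of compound 4.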